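The compounds below may be only part of what the source reports. "The series", "measured", "known", "first", "only" and "open" are said of these compounds alone.

Measured compounds:
- compound 1 `Cc1cc(C)c(NC(=O)N(Cc2cccc(-c3csc(C)n3)c2)C2CCCCCC2)c(C)c1`: 180 nM
- compound 2 `Cc1cc(C)c(NC(=O)N(Cc2ccc(-c3cccs3)cc2)C2CCCCCC2)c(C)c1`: 22 nM
- compound 3 `Cc1cc(C)c(NC(=O)N(Cc2ccc(-n3cccn3)cc2)C2CCCCCC2)c(C)c1`: 70 nM

All three share one core and differ only in the group hanging from the benzyl ring. In an assay on microsomes from intestine for inhibition of acyl-CoA:cholesterol acyltransferase (Oryctolagus cuniculus) (a higher number here means a weaker inhibitor, a lower number a stronger inhibitor), compound 3 stands second highest of the three numbers: compound 1 sits above it by a gap beyond the scatter, and compound 2 sits below it by a gap beyond the scatter. Among the measured compounds shown here, the one measured step that touches the same position is a 3.2-fold higher number from compound 2 to compound 3 (0.50 log units; beyond the scatter), a modest weakening when a carbon-linked five-membered ring gave way to a nitrogen-linked one.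

Compound 4 `Cc1cc(C)c(NC(=O)N(Cc2ccc(-n3cncn3)cc2)C2CCCCCC2)c(C)c1` is made from compound 3 by the change (1H-1,2,4-triazol-1-yl in place of 1H-pyrazol-1-yl on an aromatic carbon). For the measured compounds named here, no measured pair shows exactly this swap, so the expectation rests on the direction seen in the step from compound 2 to compound 3, applied loosely: adding a further ring nitrogen is expected to nudge the number upward, though perhaps not beyond the scatter. The step expected for compound 4 is a 1.7-fold higher number from compound 3 to compound 4 (0.23 log units; within the scatter), giving an estimate for compound 4 of 120 nM, within a range of 40 nM to 350 nM.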

Compound 4, half-maximal inhibitory concentration: 26 nM
Compound 4: middle estimate off by 4.6-fold (0.66 log units), on the high side; the whole stated range lies above it.
By their numbers in this assay, from the lowest: compounds 2 and 4 (each within the scatter of the next); then compound 3; then compound 1.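

At this place, para to a large group, this assay gives a 2.7-fold lower number from compound 3 to compound 4 (0.43 log units; beyond the scatter) when 1H-1,2,4-triazol-1-yl replaces 1H-pyrazol-1-yl, so exchanging one ring carbon for a nitrogen lowers the number. The comparison with the thiophene gives a 1.2-fold higher number from compound 2 to compound 4 (0.07 log units; within the scatter), which means that the weakening seen with 1H-pyrazol-1-yl does not extend to every nitrogen-linked five-membered ring here. No supporting measurement bears on why this exchange acts as it does.

As far as these compounds go, it remains open whether 1H-imidazol-1-yl or 1H-tetrazol-1-yl at this place would track compound 3 or compound 4. From the compounds shown here alone, it is also open how a non-aromatic group such as morpholine, or a carboxylic acid, would fare on the same ring.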